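The source may hold more compounds than are shown below. What is called first, only, known or untested is meant among the compounds shown, and "the series" means these compounds.

Measured in a functional assay on A549 cells (Homo sapiens) for inhibition, read by sulforhodamine B assay, with a stated time of 48 h; on this read-out higher numbers stand for weaker inhibition of growth and lower numbers for stronger inhibition of growth:
- Compound 1 `COc1ccc2c(c1)NC(=O)CN2c1nc(Nc2cccc(C#N)c2)nc2ccccc12`: 75.4 nM
- Compound 2 `COc1ccc2c(c1)NC(=O)CN2c1nc(NC2CCCC2)nc2ccccc12`: 7.67 nM

Compound 2 holds the lower of the two numbers. Compound 3 `CCOc1nc(N2CC(=O)Nc3cc(OC)ccc32)c2ccccc2n1` is unmeasured and differs from it as follows: ethoxy in place of cyclopentylamino on an aromatic carbon. This puts ethoxy in place of cyclopentylamino on an aromatic carbon. Within the data shown here, the only measured step, a 9.8-fold lower number from compound 1 to compound 2 (0.99 log units; beyond the scatter), changes the substituent on that amino nitrogen and lies beyond the scatter. Among the measured compounds shown here, no measured compound lacks that nitrogen, so the read-across is weak. A modest move toward weaker inhibition in this assay is expected, estimated as a 3.3-fold higher number from compound 2 to compound 3 (0.51 log units; beyond the scatter). The estimate for compound 3 is 25 nM, with an expected range of 5 nM to 120 nM.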

Compound 3, concentration for 50% growth inhibition: 16.7 nM
For compound 3 the middle estimate is 1.5-fold (0.18 log units) above the measured one, and the stated range covers the measured number.
By their numbers in this assay, from the lowest: compound 2; then compound 3; then compound 1.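

At this aromatic carbon between two ring nitrogen atoms, the amino nitrogen is not needed for a low number in this assay. Ethoxy, with no ring and no hydrogen-bond donor, costs only a modest amount against cyclopentylamino (a 2.2-fold higher number from compound 2 to compound 3 (0.34 log units; beyond the scatter)) and still improves on (3-cyanophenyl)amino (a 4.5-fold lower number from compound 1 to compound 3 (0.65 log units; beyond the scatter)). No measurement offers an explanation for either step.

Open, going by these compounds, is whether a shorter or longer alkoxy chain, such as methoxy or butoxy, would follow ethoxy. Also open, on these data alone, is how a cyclopentyloxy group would compare with cyclopentylamino, which would separate the ring from the linking atom.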